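This account rests on a few compounds, and the source may have more. Where it says the series, first, only, none or still open, it means among the compounds named here.

Measured so far:
compound 1, `Cc1ccc2nc(N3CCCc4ccc(F)cc4C3)cc(NCC3(N)COC3)c2c1`: > 100000 nM
compound 2, `CC(O)CNc1cc(N2CCc3ccccc3C2)nc2ccccc12`: 89000 nM

Both compounds were tested in an ADME assay on HEp-2 cells (Homo sapiens) for cytotoxicity, read by CCK-8 assay, with a stated time of 5 days; a higher number here means that more compound is tolerated, a lower number that less compound is tolerated. For compound 1 the value > 100000 nM is a limit of the assay rather than a number, so all that is known of compound 1 is the limit of > 100000 nM in this assay, at which 1 of the 2 values shown sits. Compound 2 gives 89000 nM in this assay. For the measured compounds named here, no two of the measured compounds differ in a single place, so no measured step exists from which the effect of one change could be read.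

Compound 3, `Cc1ccc2nc(N3CCCc4ccc(F)cc4C3)cc(NCC3CCCCN3)c2c1`, is not yet measured. It differs from compound 1 in one place: piperidin-2-yl in place of 3-aminooxetan-3-yl on a saturated chain carbon bound to a nitrogen on an aromatic ring. With compound 1 known only as a limit, the size of the step is uncertain; a modest downward step, or none beyond the usual scatter, is expected, an at least 1.6-fold lower number from compound 1 to compound 3 (0.22 log units; that floor lies within the scatter). Compound 3 is therefore estimated at 60000 nM, in a range from 20000 nM to 150000 nM.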

Compound 3, half-maximal cytotoxic concentration: 23000 nM
Compound 3: middle estimate off by 2.6-fold (0.42 log units), on the high side; low and high end bracket the measured number.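

In this assay, piperidin-2-yl in place of 3-aminooxetan-3-yl on a saturated chain carbon bound to a nitrogen on an aromatic ring gives an at least 4.3-fold lower number from compound 1 to compound 3 (0.63 log units; beyond the scatter). For the compounds shown here, this is the first single change that can be read in this set, and it shows that the group at this place can alter how much compound the cells tolerate while the rest of the molecule stays the same. The value for compound 1 is a limit of the assay and not a number, so the true step could be larger: the limit of > 100000 nM in this assay, at which 1 of the 3 values shown sits.

Going by these compounds, whether the lower number follows the six-membered ring or the loss of the oxygen stays open, for the two groups differ in both. On these data alone, how morpholin-2-yl, which holds an oxygen in a six-membered ring, or an open-chain amine would behave at this place also remains unknown.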